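A few compounds are considered here, and "the series" means these few. Any claim that something is new, unique, unknown or untested is made for them only; others in the source may bear on it.

In a functional assay on MV4-11 cells (Homo sapiens) for antiproliferative activity, read by luminescence and CellTiter-Glo, with a stated time of 72 h (a higher number here means a weaker inhibitor, a lower number a stronger inhibitor), compound 1 `Cc1ccc(Cn2nc(Nc3ccc(C#N)cc3)c3ccc(-c4c(C)noc4C)cc32)cc1` gives 5800 nM, while compound 2 `CNc1cc(-c2ccc3cnn(Cc4ccc(F)c(F)c4)c3c2)cn(C)c1=O` gives 320 nM. Compound 2 therefore holds the lower of the two numbers, making it the stronger inhibitor of this pair, and the gap lies beyond the usual scatter of repeat measurements.

Compound 3 `CCOC(=O)Cn1ncc2ccc(-c3cc(NC)c(=O)n(C)c3)cc21` has not yet been measured in this assay. Its structure departs from compound 2 in one place: ethoxycarbonyl in place of 3,4-difluorophenyl on a saturated chain carbon bound to an aromatic nitrogen. In plain terms, ethoxycarbonyl takes the place of 3,4-difluorophenyl on a saturated chain carbon bound to an aromatic nitrogen. Read one bond further out, 3,4-difluorobenzyl becomes (ethoxycarbonyl)methyl.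

Going by the values given here, no measured pair here shows a change of this kind, so any forecast is a judgement rather than a trend. Starting from compound 2 at 320 nM, the loss of a whole aromatic ring is expected to push the number up, not down. The estimated move is a 6.3-fold higher number from compound 2 to compound 3 (0.80 log units; beyond the scatter), a weakening expected to lie beyond the scatter. The estimate for compound 3 is 2000 nM, with an expected range of 600 nM to 8000 nM.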

Compound 3, half-maximal inhibitory concentration: 8770 nM
For compound 3 the middle estimate is 4.4-fold (0.64 log units) below the measured one; measured number above the stated range.
By their numbers in this assay, from the lowest: compound 2; then compounds 1 and 3 (each within the scatter of the next).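

In this assay, going by these compounds alone, the step of a 27-fold higher number from compound 2 to compound 3 (1.44 log units; beyond the scatter) comes from replacing 3,4-difluorobenzyl with (ethoxycarbonyl)methyl, and it is the only direct evidence here that the group on this saturated chain carbon bound to an aromatic nitrogen has a large bearing on the number. The change is not a single simple one: a six-membered aromatic ring of carbon only and both fluorine atoms leave, while a group with no ring, one double bond and two hydrogen-bond acceptors enters, so this one pair cannot show which of these differences matters. No measurement shown here gives a reason for the weakening, so it stands as an observation without an explanation.

The compounds shown leave open whether the aromatic ring, its two fluorine atoms or the ethoxycarbonyl group itself accounts for most of the step. An unsubstituted benzyl group would test the fluorine atoms, while a cyclohexylmethyl group would test the aromatic ring, and a carboxylic acid or a primary amide in place of the ethoxycarbonyl group would show whether other non-ring groups behave in the same way.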